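Does a dichlorophenyl on sulfur stay tolerated?

The source may hold more compounds than are shown below. What is called first, only, known or untested is meant among the compounds shown, and "the series" means these compounds.

Measured in an ADME assay on cells (Homo sapiens) for cytotoxicity, read by resazurin assay, with a stated time of 5 days; a higher number here means that more compound is tolerated, a lower number that less compound is tolerated:
- compound 1 `COc1ccc(-c2nc(CC(=O)c3cccc(Cl)c3)nc3ccsc23)cn1`: 30000 nM
- compound 2 `COc1ccc(-c2nc(CSc3cccc(Cl)c3Cl)nc3ccsc23)cn1`: > 50000 nM (a limit)
- compound 3 `COc1ccc(-c2nc(CSCc3cccc(Cl)c3)nc3ccsc23)cn1`: > 50000 nM (a limit)

Compound 3 therefore has no exact number, only a limit. Compound 4 `COc1ccc(-c2nc(CSc3cc(Cl)ccc3Cl)nc3ccsc23)cn1` carries 2,5-dichlorophenyl in place of 3-chlorobenzyl on a sulfur. The measured steps give little to size this change: an at least 1.6-fold higher number from compound 1 to compound 2 (0.22 log units; that floor lies within the scatter) and an at least 1.6-fold higher number from compound 1 to compound 3 (0.22 log units; that floor lies within the scatter) are both floors, and a step that the two limits leave unreadable from compound 2 to compound 3. The nearest measured case is compound 2, with 2,3-dichlorophenyl on the same sulfur, at > 50000 nM. No step beyond the scatter is therefore expected in this assay, and another limit is likely. The expected change is a number no higher from compound 3 to compound 4 (the limit leaves the size open). For compound 4 the estimate is 50000 nM, with an expected range of 25000 nM to 100000 nM.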

Compound 4, half-maximal cytotoxic concentration: > 50000 nM
Compound 4: a limit, no number (the forecaster's own chance of this, stated with the estimate: 75%); the middle value sits exactly at the limit.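

In this assay compound 4 gives > 50000 nM, which is a limit and not a number, so a second dichlorophenyl group on the sulfur also reaches it. Among these compounds, the one readable step is an at least 1.6-fold higher number from compound 1 to compound 4 (0.22 log units; that floor lies within the scatter). The steps to compound 4 from compound 2 and compound 3 cannot be read, because these compounds share one limit: the limit of > 50000 nM in this assay, at which 3 of the 4 values shown sit.

On these data alone, how much compound these three tolerate beyond that limit stays open, so any differences among them remain hidden. Also open, as far as these compounds go, is whether an amine in place of 2,5-dichlorophenyl on the sulfur would reach the same limit.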